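Series notes: the step from compound 3 to compound 4

This account rests on a few compounds, and the source may have more. Where it says the series, first, only, none or still open, it means among the compounds named here.

Measured compounds:
compound 1 `COc1ccc(CNC(=O)c2cc(-c3cc(C)cc(C)c3)cnc2-c2cccnc2)cc1` gives 2980 nM
compound 2 `Cc1cc(C)cc(-c2cnc(-c3cccnc3)c(C(=O)NCc3ccc(F)c(C)c3)c2)c1` gives 1110 nM
compound 3 `Cc1cc(C)cc(-c2cnc(-c3cccnc3)c(C(=O)NCc3ccc(C(F)(F)F)c(F)c3)c2)c1` gives 236 nM

All three were read in an assay on isolated protein for displacement of a labelled ligand from Orexin/Hypocretin receptor type 1 (Homo sapiens), read by scintillation counting, with a stated time of 60 min; a lower number here means a stronger inhibitor, a higher number a weaker inhibitor. Compound 3 has the lowest number of the three; compound 2 is nearest, separated by a 4.7-fold lower number from compound 2 to compound 3 (0.67 log units; beyond the scatter), and compound 1 is furthest, separated by a 13-fold lower number from compound 1 to compound 3 (1.10 log units; beyond the scatter). Compound 4 `COc1ccc(CNC(=O)c2cc(-c3cc(C)cc(C)c3)cnc2-c2cccnc2)cc1OC` is not yet measured. It differs from compound 3 by 3,4-dimethoxyphenyl in place of 3-fluoro-4-(trifluoromethyl)phenyl on a saturated chain carbon bound to an amide-type nitrogen. All three measured steps bear on this change, since each swaps the aryl group at the same place: a 2.7-fold lower number from compound 1 to compound 2 (0.43 log units; beyond the scatter), a 4.7-fold lower number from compound 2 to compound 3 (0.67 log units; beyond the scatter) and a 13-fold lower number from compound 1 to compound 3 (1.10 log units; beyond the scatter). Compound 1 carries the 4-methoxyphenyl, the closest measured relative of the 3,4-dimethoxyphenyl entering in compound 4, and compound 1 gives 2980 nM. Among the measured compounds shown here, the move to compound 4 is therefore expected to raise the number by a large step, roughly undoing a 13-fold lower number from compound 1 to compound 3 (1.10 log units; beyond the scatter); the second methoxy has no measured precedent in this set. The step expected is a 13-fold higher number from compound 3 to compound 4 (1.10 log units; beyond the scatter). Compound 4 is estimated at 3000 nM, within a range from 1000 nM to 9000 nM.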

Compound 4, inhibition constant: 462 nM
The estimate for compound 4 lay 6.5-fold (0.81 log units) above the measured number, and the stated range ends above it.
By their numbers in this assay, from the lowest: compounds 3 and 4 (each within the scatter of the next); then compound 2; then compound 1.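

In this assay, at the saturated chain carbon bound to an amide-type nitrogen, a ring with no fluorine can match the 3-fluoro-4-(trifluoromethyl)phenyl: the 3,4-dimethoxyphenyl sits level with it (a 2.0-fold higher number from compound 3 to compound 4 (0.29 log units; within the scatter)). Methoxy in place of hydrogen on an aromatic carbon is a clear gain on the 4-methoxyphenyl (a 6.5-fold lower number from compound 1 to compound 4 (0.81 log units; beyond the scatter)), and the 3,4-dimethoxyphenyl also gives a lower number than the 4-fluoro-3-methylphenyl (a 2.4-fold lower number from compound 2 to compound 4 (0.38 log units; beyond the scatter)). No measurement on hand accounts for the effect of this added methoxy.

Open, going by these compounds, is whether a hydroxy or an ethoxy in place of either methoxy of the 3,4-dimethoxyphenyl holds the number. Also open, on these data alone, is how an amine or a carboxylic acid on this aryl group would read, since the rest of the core stays fixed across these compounds.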